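Compound 1 and its 4-(trifluoromethyl)phenyl analogue

The source may report more compounds than this note shows. Statements on the series, on what has been measured and on what is new or still open speak of the compounds shown alone.

The measured compounds:
Compound 1 `COc1cc(NC(C)CCCNC(=O)Nc2cccc(F)c2)c2ncccc2c1`: in a functional assay on HeLa cells (Homo sapiens) for inhibition, read by MTT assay, with a stated time of 72 h (on this read-out higher numbers stand for weaker inhibition and lower numbers for stronger inhibition), compound 1 gives 18000 nM.
Compound 2 `COc1cc(NC(C)CCCNC(=O)Nc2cccc(Cl)c2)c2ncccc2c1`: in this assay compound 2 gives 17000 nM.
Compound 3 `COc1cc(NC(C)CCCNC(=O)NNC(=O)Nc2cccc(F)c2)c2ncccc2c1`: in this assay compound 3 reaches only > 250000 nM, which is a limit of the assay and not a number.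

Compound 1 has the higher of the two numbers that are not limits, but the step of a 1.1-fold lower number from compound 1 to compound 2 (0.02 log units; within the scatter) is within the scatter, so compounds 1 and 2 cannot be told apart. Compound 3 sits at the limit (the limit of > 250000 nM in this assay, at which 1 of the 3 values shown sits), and the steps of an at least 13-fold higher number from compound 1 to compound 3 (1.14 log units; beyond the scatter) and an at least 14-fold higher number from compound 2 to compound 3 (1.16 log units; beyond the scatter) are both large.

Compound 4 `COc1cc(NC(C)CCCNC(=O)Nc2ccc(C(F)(F)F)cc2)c2ncccc2c1` has not been measured in this assay. It differs from compound 1 in one place: 4-(trifluoromethyl)phenyl in place of 3-fluorophenyl on an amide-type nitrogen. Going by the values given here, of the measured steps, only the one from compound 1 to compound 2 changes the substituent on an aryl group that stays directly on the amide-type nitrogen, and that step, a 1.1-fold lower number from compound 1 to compound 2 (0.02 log units; within the scatter), was within the scatter. The steps to compound 3 replace the aryl group by a ((3-fluorophenyl)carbamoyl)amino group and do not bear on compound 4. A step within the scatter, in either direction, is therefore expected for a 1.2-fold lower number from compound 1 to compound 4 (0.08 log units; within the scatter). Compound 4 is accordingly estimated at 15000 nM, with a range from 5000 nM to 45000 nM.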

Compound 4, half-maximal inhibitory concentration: 8300 nM
Beside the measured number, compound 4's estimate is 1.8-fold (0.26 log units) above it, within the range that was stated.
By their numbers in this assay, from the lowest: compound 4; then compounds 2 and 1 (each within the scatter of the next). At a limit, above all of these: compound 3.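

On the aryl group held directly on the amide-type nitrogen, chloro in place of fluoro had given a 1.1-fold lower number from compound 1 to compound 2 (0.02 log units; within the scatter), whereas 4-(trifluoromethyl)phenyl in place of 3-fluorophenyl gives a 2.2-fold lower number from compound 1 to compound 4 (0.34 log units; beyond the scatter), and in place of 3-chlorophenyl it gives a 2.0-fold lower number from compound 2 to compound 4 (0.31 log units; beyond the scatter). The number can therefore move beyond the scatter with a change on this aryl group, though only modestly, and that shift remains small beside the one that separates the ((3-fluorophenyl)carbamoyl)amino group from 4-(trifluoromethyl)phenyl on the same nitrogen, an at least 30-fold lower number from compound 3 to compound 4 (1.47 log units; beyond the scatter). Compound 3 is held at a limit of the assay and has no number: the limit of > 250000 nM in this assay, at which 1 of the 4 values shown sits.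

Compound 4 differs from compounds 1 and 2 in both the substituent and the place given in its group name, so the compounds shown do not separate the two, which 3-(trifluoromethyl)phenyl or 4-fluorophenyl on the same nitrogen would begin to do. Also open, as far as these compounds go, is how a phenyl ring carrying an amine or a carboxylic acid would read, and whether a longer chain on the shared core would move the number at all.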